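The source may report more compounds than this note shows. Statements on the series, on what has been measured and on what is new or still open speak of the compounds shown alone.

Measured so far in a functional assay on the whole organism for inhibition, with Rattus norvegicus as the target; a lower number here means that less compound is needed, a higher number that more compound is needed for the effect:
Compound 1 `CC1CC/C(=N\Nc2cccc(Br)c2)c2ncc(C(=O)O)c(=O)n21` gives 0.4 umol/kg.
Compound 2 `CCOc1cccc(N/N=C2\CCC(C)n3c2ncc(C(=O)O)c3=O)c1` gives 0.2 umol/kg.
Compound 3 `Cc1cccc(N/N=C2\CCC(C)n3c2ncc(C(=O)O)c3=O)c1` gives 0.4 umol/kg.

Compound 3 stands level with compound 1 on these numbers, and the step of a 2.0-fold higher number from compound 2 to compound 3 (0.30 log units; within the scatter) is within the scatter, as are a 2.0-fold lower number from compound 1 to compound 2 (0.30 log units; within the scatter) and no change at the digits printed from compound 1 to compound 3 (within the scatter). Compound 4 `CC1CC/C(=N\Nc2cccc(C(=O)O)c2)c2ncc(C(=O)O)c(=O)n21` differs from compound 3 by carboxy in place of methyl on an aromatic carbon. Among the compounds with values here, no measured step involves a carboxy group; the three measured steps each exchange one group on an aromatic carbon for another and all stay within the scatter, so they offer little guidance on this larger change. For compound 4 the expected value in this assay is 0.8 umol/kg, with a range from 0.2 umol/kg to 4 umol/kg. That estimate means an expected step of a 2.0-fold higher number from compound 3 to compound 4 (0.30 log units; within the scatter), modest but uncertain.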

Compound 4, dose for 50% inhibition: 26.6 umol/kg
Compound 4: the middle estimate sits 33-fold (1.52 log units) below what was measured; measured number outside the range, above it.
By their numbers in this assay, from the lowest: compounds 2, 1 and 3 (each within the scatter of the next); then compound 4.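

In this assay, bromo, ethoxy and methyl on this aromatic carbon gave values within the scatter of one another, so the position seemed to accept quite different groups. Carboxy breaks that picture, with a 67-fold higher number from compound 3 to compound 4 (1.82 log units; beyond the scatter) and a 67-fold higher number from compound 1 to compound 4 (1.82 log units; beyond the scatter) and a 130-fold higher number from compound 2 to compound 4 (2.12 log units; beyond the scatter) all counting as large steps towards needing more compound. So this position does not accept every group, and compound 4 is the one compound here that goes against the flat pattern. Nothing available here explains the jump. From the compounds shown here alone, whether a methyl ester, an amide or an amine in this place would bring a similar rise remains open.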